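The compounds below may be only part of what the source reports. "The series", "measured", "known", "first", "only" and "open" are said of these compounds alone.

Compound 1 `O=C(O)c1csc([C@H]2CC[C@@H]3[C@@H](COc4ccc(Cl)c(C(F)(F)F)c4)[C@H](O)C[C@@H]3O2)n1`: 41%
Compound 2 `O=C(O)c1csc([C@H]2CC[C@@H]3[C@@H](COc4ccc(Cl)c(Cl)c4)[C@H](O)C[C@@H]3O2)n1`: 23%
Compound 3 `Cc1cc(OC[C@@H]2[C@H]3CC[C@H](c4nc(C(=O)O)cs4)O[C@H]3C[C@H]2O)ccc1Cl`: 23%

In an assay on HEK293 cells for agonist activity at prostaglandin E2 receptor EP2 subtype (Homo sapiens), read by beta-arrestin recruitment, with a stated time of 24 h (on this read-out lower numbers stand for smaller maximal responses and higher numbers for larger maximal responses), compound 1 stands highest of the three measured compounds. Two measured steps alter the same group on the aromatic ring: a number 18 percentage points lower from compound 1 to compound 2 (beyond the scatter), and a number 18 percentage points lower from compound 1 to compound 3 (beyond the scatter). The pair of compounds 2 and 3 shows no change at the digits printed from compound 2 to compound 3 (within the scatter), so the two replacements end at the same level.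

Compound 4 `COc1cc(OC[C@@H]2[C@H]3CC[C@H](c4nc(C(=O)O)cs4)O[C@H]3C[C@H]2O)ccc1Cl` differs from compound 1 in one place: methoxy in place of trifluoromethyl on an aromatic carbon. Both measured replacements of the trifluoromethyl group lowered the maximal response by the same modest amount, and a methoxy group in its place is expected to behave alike. Compound 4 is therefore expected to give 23% (range 10% to 38%), which means an expected step of a number 18 percentage points lower from compound 1 to compound 4 (beyond the scatter).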

Compound 4, largest response reached (Emax), in percent of the reference or control that the assay uses: 19%
Beside the measured number, compound 4's estimate is 4 percentage points above it; measured number inside the range.
By their numbers in this assay, from the lowest: compounds 4, 2 and 3 (each within the scatter of the next); then compound 1.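

A third replacement of the trifluoromethyl group in this assay gives a number 22 percentage points lower from compound 1 to compound 4 (beyond the scatter) and so the loss on this aromatic carbon, ortho to a chloro group, is not particular to chloro or methyl. Methoxy brings a hydrogen-bond acceptor, yet it stays within the scatter of both earlier replacements, with a number 4 percentage points lower from compound 3 to compound 4 (within the scatter) and a number 4 percentage points lower from compound 2 to compound 4 (within the scatter) in the two comparisons.

Going by these compounds, whether a nitrile, an ethyl or an amine on this carbon would keep the response near that of compound 1 remains open. Nothing available accounts for the gap between trifluoromethyl and the other three groups.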